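The source may hold more compounds than are shown below. What is called first, only, known or untested is meant among the compounds shown, and "the series" means these compounds.

Measured compounds and their values in an assay on HEK293 cells for displacement of a labelled ligand from growth hormone secretagogue receptor type 1 (Homo sapiens), with a stated time of 60 min; a higher number here means a weaker inhibitor, a lower number a stronger inhibitor:
Compound 1, `COc1ccc(-n2cc3nc(-c4cccnc4C)n(C[C@H]4CCCN(C[C@H]5CCCO5)C4)c(=O)c3n2)cc1`: compound 1 gives 52 nM
Compound 2, `CCO[C@@H](C)CN1CCC[C@H](Cn2c(-c3cccnc3C)nc3cn(-c4cccc(OC)c4)nc3c2=O)C1`: compound 2 gives 5 nM
Compound 3, `Cc1ncccc1-c1nc2cn(-c3cccc(OC(F)F)c3)nc2c(=O)n1C[C@H]1CCCN(C[C@H]2CCCO2)C1`: compound 3 gives 27 nM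

Among these three, compound 2 has the lowest number, and its gaps to compound 3 and to compound 1 both lie beyond the usual scatter. Compound 4, `CCO[C@H](C)CN1CCC[C@H](Cn2c(-c3cccnc3C)nc3cn(-c4cccc(OC)c4)nc3c2=O)C1`, is related to compound 2 as follows: the two compounds have the same atoms and bonds and differ only in configuration as drawn: 1 of 2 stereo elements differ; a stereocentre at a saturated chain carbon is drawn S in compound 2 and R in compound 4. For the measured compounds named here, the only measured step, a 1.9-fold lower number from compound 1 to compound 3 (0.28 log units; within the scatter), swaps a group on an aromatic nitrogen and says nothing about a change of configuration, so no measured step bears on this move. A flipped stereocentre can shift binding either way; with nothing to guide the direction, a modest weakening is expected for compound 4, a 2.4-fold higher number from compound 2 to compound 4 (0.38 log units; beyond the scatter). Compound 4 is therefore estimated at 12 nM, with a range from 3 nM to 50 nM.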

Compound 4, half-maximal inhibitory concentration: 40 nM
Estimate against measurement, compound 4: 3.3-fold (0.52 log units) below, within the range that was stated.
By their numbers in this assay, from the lowest: compound 2; then compounds 3, 4 and 1 (each within the scatter of the next).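

In this assay, redrawing a stereocentre at a saturated chain carbon from S to R gives an 8.0-fold higher number from compound 2 to compound 4 (0.90 log units; beyond the scatter), so binding in this series is sensitive to configuration at this carbon. The earlier step changed only a group on an aromatic nitrogen and could not show this. The gap can be assigned to this single stereocentre: the fact that compounds 2 and 4 differ only in the configuration as drawn.

On these data alone, it remains open whether S would still give the lower number with a hydroxyl group or a longer chain in place of the ethoxy group. As far as these compounds go, the effect of inverting the other stereocentre also remains open.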